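From Amide to Urea: Estimating Compound 4

The source may hold more compounds than are shown below. What is called first, only, known or untested is meant among the compounds shown, and "the series" means these compounds.

Measured compounds:
compound 1 `Cc1ccccc1C(=O)NC1CCN(c2ncnc3[nH]ncc23)CC1`, 6260 nM
compound 2 `O=C(NC1CCN(c2ncnc3[nH]ncc23)CC1)c1ccccc1Cl`, 5240 nM
compound 3 `Cc1cccc(C)c1NC(=O)NC1CCN(c2ncnc3[nH]ncc23)CC1`, 2160 nM

In an assay on isolated protein for inhibition of serine/threonine-protein kinase PAK 1 (Homo sapiens), read by ADP-Glo, with a stated time of 40 min (a higher number here means a weaker inhibitor, a lower number a stronger inhibitor), compound 1 gives the highest of the three numbers; compound 2 sits within the scatter of it (a 1.2-fold lower number from compound 1 to compound 2 (0.08 log units; within the scatter)), whereas compound 3 is separated beyond the scatter (a 2.9-fold lower number from compound 1 to compound 3 (0.46 log units; beyond the scatter)). Compound 4 `O=C(Nc1ccccc1Cl)NC1CCN(c2ncnc3[nH]ncc23)CC1` is reached from compound 1 by the change ((2-chlorophenyl)amino in place of 2-methylphenyl on a carbonyl carbon). Among the measured compounds shown here, two measured steps bear on this: the urea of compound 3 gave a 2.9-fold lower number from compound 1 to compound 3 (0.46 log units; beyond the scatter) and a 2.4-fold lower number from compound 2 to compound 3 (0.38 log units; beyond the scatter), while chloro for methyl gave only a 1.2-fold lower number from compound 1 to compound 2 (0.08 log units; within the scatter). A modest step downward is therefore expected for compound 4, estimated as a 2.1-fold lower number from compound 1 to compound 4 (0.32 log units; beyond the scatter), giving 3000 nM with a range from 1500 nM to 6000 nM.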

Compound 4, half-maximal inhibitory concentration: 560 nM
Compound 4: the middle estimate sits 5.4-fold (0.73 log units) above what was measured, outside the stated range (below it).
By their numbers in this assay, from the lowest: compound 4; then compound 3; then compounds 2 and 1 (each within the scatter of the next).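

In this assay, the change from amide to urea with the 2-chlorophenyl group kept gave a 9.4-fold lower number from compound 2 to compound 4 (0.97 log units; beyond the scatter), and the full change gave an 11-fold lower number from compound 1 to compound 4 (1.05 log units; beyond the scatter), so this carbonyl carbon tolerates far more gain than compound 3 had indicated. The aryl group on the amide-type nitrogen of the urea also matters, with a 3.9-fold lower number from compound 3 to compound 4 (0.59 log units; beyond the scatter), whereas the amides compound 1 and compound 2 lay within the scatter of each other. No evidence is available to account for this gain.

The compounds shown leave open how a urea bearing 2-methylphenyl would compare with compound 4. They also leave open what an unsubstituted phenyl or a methoxyphenyl group would give on the same urea.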